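A Diol Chain Replaces the Aminoethyl Amide Arm

The compounds below may be only part of what the source reports. "The series", "measured", "known", "first", "only" and "open" are said of these compounds alone.

Compound 1 `CCn1c(C(=O)NCC#N)ccc1C(CC)(CC)c1ccc(OCCC(O)(CC)CC)c(C)c1`: 17800 nM
Compound 2 `CCn1c(C(=O)NCCN)ccc1C(CC)(CC)c1ccc(OCCC(O)(CC)CC)c(C)c1`: 2420 nM
Compound 3 `C#CC(C)OC(=O)c1ccc(C(CC)(CC)c2ccc(OCCC(O)(CC)CC)c(C)c2)n1CC`: 14800 nM

In a functional assay on PC-3 cells (Homo sapiens) for antiproliferative activity, read by MTT assay, with a stated time of 48 h (on this read-out lower numbers stand for stronger inhibition and higher numbers for weaker inhibition), compound 2 holds the lowest number of the three: a 7.4-fold lower number from compound 1 to compound 2 (0.87 log units; beyond the scatter), and a 6.1-fold higher number from compound 2 to compound 3 (0.79 log units; beyond the scatter). Compound 4 `CCn1c(C(=O)NC(CO)CCO)ccc1C(CC)(CC)c1ccc(OCCC(O)(CC)CC)c(C)c1` differs from compound 2 in one place: 3-hydroxy-1-(hydroxymethyl)propyl in place of 2-aminoethyl on an amide-type nitrogen. For the measured compounds named here, no measured step swaps these two groups directly. Going by the values given here, the steps that bear on it are the one from compound 1 to compound 2, where aminomethyl entered, and the one from compound 2 to compound 3, where the 2-aminoethyl amide left; both were modest. Compound 4 keeps an amide but no longer carries the 2-aminoethyl group, so a modest rise in number is expected, a 3.3-fold higher number from compound 2 to compound 4 (0.52 log units; beyond the scatter). Compound 4 is estimated at 8000 nM, with a range from 2500 nM to 25000 nM.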

Compound 4, half-maximal inhibitory concentration: 8760 nM
Estimate against measurement, compound 4: 1.1-fold (0.04 log units) below; low and high end bracket the measured number.
By their numbers in this assay, from the lowest: compound 2; then compounds 4, 3 and 1 (each within the scatter of the next, the first and the last beyond it).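

In this assay, keeping the amide but trading 2-aminoethyl for the larger 3-hydroxy-1-(hydroxymethyl)propyl gives a 3.6-fold higher number from compound 2 to compound 4 (0.56 log units; beyond the scatter), so the amide alone does not secure the low number of compound 2. Against cyanomethyl, the new group gives a 2.0-fold lower number from compound 1 to compound 4 (0.31 log units; beyond the scatter), while against (1-methylprop-2-yn-1-yl)oxy it gives a 1.7-fold lower number from compound 3 to compound 4 (0.23 log units; within the scatter). No supporting evidence accounts for these steps. Open, on these data alone, is how 2-hydroxyethyl or 3-aminopropyl on this nitrogen would read, which could show whether the amine or the chain length goes with the low number of compound 2.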